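A few compounds are considered here, and "the series" means these few. Any claim that something is new, unique, unknown or untested is made for them only; others in the source may bear on it.

Compound 1 `Cc1nc(Nc2ccc(Cl)cc2)sc1C(=O)/C=C/c1ccccc1` and compound 2 `Cc1nc(Nc2ccc(Cl)c(Cl)c2)sc1C(=O)/C=C/c1ccccc1` form one pair; compound 3 `COc1cc(/C=C/C(=O)c2sc(Nc3cccc(Cl)c3)nc2C)cc(OC)c1OC` and compound 4 `COc1cc(/C=C/C(=O)c2sc(Nc3ccc(Cl)c(Cl)c3)nc2C)cc(OC)c1OC` form a second, and the difference between the two cores is not broken down here. In a functional assay on NCI-H460 cells (Homo sapiens) for cytotoxicity, read by MTT assay (on this read-out higher numbers stand for weaker inhibition and lower numbers for stronger inhibition), compound 1 gives only a limit, > 25000 nM. In this assay compound 2 gives 22700 nM. The change chloro in place of hydrogen on an aromatic carbon made an at least 1.1-fold lower number from compound 1 to compound 2 (0.04 log units; that floor lies within the scatter). In this assay compound 3 likewise gives only a limit, > 25000 nM. Compound 4 carries the same kind of change, (chloro in place of hydrogen on an aromatic carbon); the place differs in that the entering chloro is para to a large group here, whereas in compound 2 it is meta to a large group. Both pairs start from the limit of > 25000 nM in this assay, at which 2 of the 3 values shown sit, so the measured step can only be read as a floor. The step from compound 3 to compound 4 is estimated at a number no higher from compound 3 to compound 4 (the limit leaves the size open), because compound 2 gives 22700 nM and the first pair showed only an at least 1.1-fold lower number from compound 1 to compound 2 (0.04 log units; that floor lies within the scatter). Compound 4 is therefore expected near 25000 nM, in the range 12000 nM to 60000 nM, with a limit the most likely outcome.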

Compound 4, half-maximal inhibitory concentration: > 25000 nM
Compound 4: only a limit was reported; the forecaster's own chance of this, stated with the estimate: 65%; the middle value sits exactly at the limit.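

No new step can be read from compound 3 to compound 4, as both results are limits and the chloro change between them has no measurable size in this assay: the limit of > 25000 nM in this assay, at which 3 of the 4 values shown sit.

The compounds shown leave open how far the 3,4-dichlorophenyl group of compound 4 differs from the 3-chlorophenyl group of compound 3 in cytotoxicity.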